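Sulfonyl series: carbonyl-side change from compound 2

The source may hold more compounds than are shown below. What is called first, only, known or untested is meant among the compounds shown, and "the series" means these compounds.

Three compounds of the shared core are measured in an ADME assay on microsomes from liver (Mus musculus) for metabolic stability, read by LC-MS, with a stated time of 30 min, tested at 1 uM; a higher number here means that more of the compound is left, a lower number that less of the compound is left. Compound 1 `O=C(NCc1ccc(S(=O)(=O)N2CCCCC2)cc1)c1cnc2nccn2c1` gives 0.28%. Compound 2 `O=C(NCc1ccc(S(=O)(=O)c2cccc(C(F)(F)F)c2)cc1)c1cnc2nccn2c1` gives 27%. Compound 3 `O=C(NCc1ccc(S(=O)(=O)c2ccccc2)cc1)c1cnc2nccn2c1` gives 30%. Compound 2 stands second highest of the three numbers; the gap to compound 3 is within the scatter, and compound 1 lies well below it, as the steps of a number 26.7 percentage points higher from compound 1 to compound 2 (beyond the scatter) and a number 29.7 percentage points higher from compound 1 to compound 3 (beyond the scatter) show. The step of a number 3 percentage points higher from compound 2 to compound 3 (within the scatter) is within the scatter.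

Compound 4 `O=C(NCc1ccc(S(=O)(=O)c2cccc(C(F)(F)F)c2)cc1)c1ccc2nccn2c1` is the next to be measured. It differs from compound 2 as follows: a group of 9 heavy atoms (7 carbon, 2 nitrogen; one five-membered aromatic ring with 2 hetero atoms, one six-membered aromatic ring with 1 hetero atom) in place of a group of 9 heavy atoms (6 carbon, 3 nitrogen; one five-membered aromatic ring with 2 hetero atoms, one six-membered aromatic ring with 2 hetero atoms), on a carbonyl carbon. Among the measured compounds shown here, all three measured steps concern the group on the sulfonyl sulfur or the trifluoromethyl on that ring; none touches the group on the carbonyl carbon, so no measured step bears on this change. With nothing to anchor a direction, the step of no change at the digits printed from compound 2 to compound 4 (within the scatter) is expected to be none beyond the scatter. Compound 4 is therefore estimated at 27%, within a range from 8% to 48%.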

Compound 4, percent of the compound remaining: 17%
Compound 4: the middle estimate sits 10 percentage points above what was measured; measured number inside the range.
By their numbers in this assay, from the lowest: compound 1; then compounds 4, 2 and 3 (each within the scatter of the next, the first and the last beyond it).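

In this assay, among the compounds shown here, the exchange on the carbonyl carbon reads as a number 10 percentage points lower from compound 2 to compound 4 (within the scatter) and is the first measured step at this position. With the 3-(trifluoromethyl)phenyl group kept on the sulfonyl sulfur, a group with 2 hydrogen-bond acceptors thus stands in for one with 3 without a difference that can be told from the scatter, whereas the step away from piperidin-1-yl on the sulfonyl sulfur lay beyond it. No measured evidence bears on this result.

Going by these compounds, whether the same exchange on the carbonyl carbon reads alike with phenyl on the sulfonyl sulfur, as in compound 3, stays open. Also open, on these data alone, is how this position responds to a group of a different kind on the carbonyl carbon, such as a plain phenyl ring or an open-chain amine.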